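A few compounds are considered here, and "the series" means these few. Any claim that something is new, unique, unknown or untested is made for them only; others in the source may bear on it.

Compound 1, `COc1cc2ncnc(N3CCCc4ccccc43)c2cc1NC(=O)/C=C/C(C)C`: in a functional assay on PC-3 cells (Homo sapiens) for antiproliferative activity, read by MTT assay, with a stated time of 72 h (on this read-out higher numbers stand for weaker inhibition and lower numbers for stronger inhibition), compound 1 gives 8430 nM.
Compound 2, `CCC/C=C/C(=O)Nc1cc2c(N3CCCc4ccccc43)ncnc2cc1OC`: in this assay compound 2 gives 2240 nM.
Compound 3, `COc1cc2ncnc(N3CCc4ccccc43)c2cc1NC(=O)/C=C/CN1CCCCC1`: in this assay compound 3 gives 4180 nM.

Compound 3 stands second highest of the three numbers. Its nearest neighbour is compound 2, whose number lies within the scatter of that of compound 3; its furthest is compound 1, also within the scatter. Compound 4, `COc1cc2ncnc(N3CCCc4ccccc43)c2cc1NC(=O)/C=C/CN1CCCCC1`, has not been measured. The change from compound 3 to compound 4 is 1,2,3,4-tetrahydroquinolin-1-yl in place of 2,3-dihydro-1H-indol-1-yl on an aromatic carbon. Within the data shown here, no measured step bears on this change: the only measured step, a 3.8-fold lower number from compound 1 to compound 2 (0.58 log units; beyond the scatter), concerns the chain on the amide and leaves the ring on the core untouched. Compounds 1 and 2 already carry the 1,2,3,4-tetrahydroquinolin-1-yl group, and their numbers stand on either side of compound 3, each within the scatter of it, so the ring change gives no sign of moving the number far. The step from compound 3 to compound 4 is therefore expected to be a 1.0-fold lower number from compound 3 to compound 4 (0.02 log units; within the scatter), none beyond the scatter. In this assay compound 4 is estimated at 4000 nM, with a range from 1500 nM to 10000 nM.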

Compound 4, half-maximal inhibitory concentration: 5780 nM
For compound 4 the middle estimate is 1.4-fold (0.16 log units) below the measured one, and the stated range covers the measured number.
By their numbers in this assay, from the lowest: compounds 2, 3, 4 and 1 (each within the scatter of the next, the first and the last beyond it).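

In this assay the exchange of 2,3-dihydro-1H-indol-1-yl for 1,2,3,4-tetrahydroquinolin-1-yl on the aromatic carbon next to the ring nitrogen gives a 1.4-fold higher number from compound 3 to compound 4 (0.14 log units; within the scatter) and so shows no shift beyond the scatter at this position, with the piperidin-1-yl chain in place. With the 1,2,3,4-tetrahydroquinolin-1-yl group held, piperidin-1-yl in place of ethyl gives a 2.6-fold higher number from compound 2 to compound 4 (0.41 log units; beyond the scatter) while (piperidin-1-yl)methyl in place of isopropyl gives a 1.5-fold lower number from compound 1 to compound 4 (0.16 log units; within the scatter) and only the first of these lies beyond the scatter. No measurement at hand accounts for these steps.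

Going by these compounds, whether the ring exchange reads the same with a propyl chain on the amide stays open. So does how a morpholin-4-yl or dimethylamino group would read in place of piperidin-1-yl.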